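Opening the Amide into a Longer Butyl Chain

The source may report more compounds than this note shows. Statements on the series, on what has been measured and on what is new or still open speak of the compounds shown alone.

Compound 1 `CCCCc1oc2ccccc2c1C(=O)c1ccc(OCC(=O)NC(C)C)cc1`: in a functional assay on MDA-MB-231 cells (Homo sapiens) for antiproliferative activity, read by MTT assay, with a stated time of 24 h (on this read-out higher numbers stand for weaker inhibition and lower numbers for stronger inhibition), compound 1 gives > 50000 nM, which is a limit of the assay rather than a number.
Compound 2 `CCCCc1oc2ccccc2c1C(=O)c1ccc(OCC(=O)N2CCCCC2)cc1`: in this assay compound 2 gives > 50000 nM, again a limit.
Compound 3 `CCCCc1oc2ccccc2c1C(=O)c1ccc(OCC(=O)N2CCOCC2)cc1`: in this assay compound 3 gives > 50000 nM, also a limit.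

Compound 2 therefore stands at the same limit as the other two measured compounds: the limit of > 50000 nM in this assay, at which 3 of the 3 values shown sit. The steps a step that the two limits leave unreadable from compound 1 to compound 2, a step that the two limits leave unreadable from compound 1 to compound 3 and a step that the two limits leave unreadable from compound 2 to compound 3 cannot be read from these limits. Compound 4 `CCCCNC(=O)CCCOc1ccc(C(=O)c2c(CCCC)oc3ccccc23)cc1` differs from compound 2 by 2-(butylcarbamoyl)ethyl in place of (piperidin-1-yl)carbonyl on a saturated chain carbon bound to an oxygen on an aromatic ring. No measured step gives a readable size for this change, as the shown values are all limits. Compound 4 is expected to remain near the limit, a step that the limit leaves unreadable from compound 2 to compound 4, with an estimated 60000 nM ranging from 20000 nM to 200000 nM.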

Compound 4, half-maximal inhibitory concentration: 38100 nM
Beside the measured number, compound 4's estimate is 1.6-fold (0.20 log units) above it; measured number inside the range.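

Compound 2 sits with compounds 1 and 3 at a limit of the assay, not a number: the limit of > 50000 nM in this assay, at which 3 of the 4 values shown sit. Among the compounds shown here, compound 4 gives the only readable number in this assay, so 3-(butylcarbamoyl)propyl at this place does leave that limit, but the steps are only an at least 1.3-fold lower number from compound 2 to compound 4 (0.11 log units; that floor lies within the scatter), an at least 1.3-fold lower number from compound 3 to compound 4 (0.11 log units; that floor lies within the scatter) and an at least 1.3-fold lower number from compound 1 to compound 4 (0.11 log units; that floor lies within the scatter). The steps among compounds 1, 2 and 3 cannot be read.

Compound 4 changes the chain length and the amide together, so neither change can be credited alone. On these data alone, whether a still longer chain, or an amine or a carboxylic acid at the chain end, would lower the number stays open.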